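The compounds below may be only part of what the source reports. "The series", "measured", "known", "first", "only" and "open" are said of these compounds alone.

In a functional assay for inhibition of metabotropic glutamate receptor 5 (Homo sapiens), read by FLIPR and calcium flux (a higher number here means a weaker inhibitor, a lower number a stronger inhibitor), compound 1 `Cc1cccc(C#CCNc2cccc(Cl)c2)n1` gives 174 nM and compound 2 `Cc1cccc(C#CCSc2cccc(Cl)c2)n1` gives 43 nM. Of these two numbers, compound 2 stands lowest, and the gap to compound 1 lies beyond the scatter of repeated measurements, so compound 2 is the stronger inhibitor of the pair. The next compound keeps the core of compound 2 and changes one place on one ring: compound 3 `Cc1cccc(C#CCSc2ccccc2)n1` differs from compound 2 by hydrogen in place of chloro on an aromatic carbon. Going by the values given here, no pair of measured compounds shows this exact change, so its size cannot be read off and has to be expected. The expectation is a moderate weakening, a step beyond the scatter toward a higher number. Compound 3 is therefore estimated at 150 nM in this assay, with a range from 50 nM to 500 nM. The expected step of a 3.5-fold higher number from compound 2 to compound 3 (0.54 log units; beyond the scatter) is a modest loss of strength.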

Compound 3, half-maximal inhibitory concentration: 589 nM
Compound 3: middle estimate off by 3.9-fold (0.59 log units), on the low side; the whole stated range lies below it.
By their numbers in this assay, from the lowest: compound 2; then compound 1; then compound 3.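

In this assay, going by these compounds alone, putting hydrogen in place of chloro gives a 14-fold higher number from compound 2 to compound 3 (1.14 log units; beyond the scatter) and this large step is the first sign that this place on the ring, meta to a large group, matters greatly for strength. Nothing else differs between the two structures, so the loss follows this one change of a single chlorine atom for a hydrogen atom. No measurement here explains why the chloro compound is so much stronger.

Only chloro and hydrogen are shown at this place, so it remains open how a fluoro, methyl or methoxy group there would compare. Also open, as far as these compounds go, is whether chloro elsewhere on the ring would do as well, and whether the same change on the core of compound 1 would produce a step of similar size.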